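Phenyl ester extension in the 7-chloroquinoline thioether series

This account rests on a few compounds, and the source may have more. Where it says the series, first, only, none or still open, it means among the compounds named here.

Compound 2 `COC(=O)/C(=C\c1ccc(OC(=O)c2ccccc2)cc1)Sc1ccnc2cc(Cl)ccc12` gives 35700 nM in a functional assay on Jurkat E6.1 cells (Homo sapiens) for cytotoxicity, read by MTT assay, with a stated time of 24 h (on this read-out lower numbers stand for stronger inhibition and higher numbers for weaker inhibition), the highest of the two numbers measured; compound 1 `COC(=O)/C(=C\c1ccc(O)cc1)Sc1ccnc2cc(Cl)ccc12` gives 5180 nM. Within the data shown here, the only measured step, a 6.9-fold higher number from compound 1 to compound 2 (0.84 log units; beyond the scatter), concerns the ester itself, not a substituent on its phenyl. Compound 3 `COC(=O)/C(=C\c1ccc(OC(=O)c2ccc(OC)cc2)cc1)Sc1ccnc2cc(Cl)ccc12` differs from compound 2 by methoxy in place of hydrogen on an aromatic carbon, on an aromatic carbon of a six-membered aromatic ring of carbon only, para to a large group. Among the measured compounds shown here, no measured step bears on this change, so the expected step of a 1.0-fold higher number from compound 2 to compound 3 (0.00 log units; within the scatter) is none beyond the scatter. For compound 3 the estimate is 36000 nM, between 15000 nM and 90000 nM.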

Compound 3, half-maximal inhibitory concentration: 11000 nM
For compound 3 the middle estimate is 3.3-fold (0.51 log units) above the measured one; measured number outside the range, below it.
By their numbers in this assay, from the lowest: compound 1; then compound 3; then compound 2.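

In this assay, the benzoyl ring of compound 2 responds to substitution: methoxy on an aromatic carbon, para to a large group, gives a 3.2-fold lower number from compound 2 to compound 3 (0.51 log units; beyond the scatter). This only partly offsets the cost of acylating the oxygen, since (4-methoxyphenyl)carbonyl in place of hydrogen on that oxygen still gives a 2.1-fold higher number from compound 1 to compound 3 (0.33 log units; beyond the scatter). No available evidence bears on this shift.

Whether the gain is particular to methoxy remains open, as the compounds shown include no ethoxy, dimethylamino or carboxylic acid at that place. As far as these compounds go, the effect of replacing the ester oxygen link with an amide also remains open.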